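The source may hold more compounds than are shown below. What is called first, only, known or untested is meant among the compounds shown, and "the series" means these compounds.

Compounds measured in a functional assay on L1210 cells (Mus musculus) for inhibition; a higher number here means a weaker inhibitor, a lower number a stronger inhibitor:

- compound 1, `O=C1/C(=C/c2ccccc2F)CCc2ccccc21`, gives 22800 nM
- compound 2, `O=C1/C(=C/c2ccccc2F)Cc2ccccc21`, gives 150000 nM
- compound 3, `O=C1/C(=C/c2ccccc2Br)CCCc2ccccc21`, gives 37000 nM

Among these three numbers, compound 1 holds the lowest one. Its nearest neighbour is compound 3, whose number lies within the usual scatter of this assay, so the two cannot be told apart on this evidence. Compound 2 stands furthest away, with a number that lies beyond the scatter of compound 1. Among the measured compounds shown here, no pair of these three compounds differs in only one place, so no single-change step can be read from them.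

Compound 4, `Cc1ccccc1/C=C1\CCc2ccccc2C1=O`, is the next compound to be measured in this assay. Its difference from compound 1 is methyl in place of fluoro on an aromatic carbon. The shared core of compound 1 is otherwise kept. For the measured compounds named here, since no measured pair shows what such a swap does here, the expected step is small: the number for compound 4 is estimated to lie close to that of compound 1, with a 1.1-fold lower number from compound 1 to compound 4 (0.06 log units; within the scatter) as the expected step, in either direction but not clearly beyond the scatter. Compound 4 is thus estimated at 20000 nM, with a range from 7000 nM to 60000 nM.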

Compound 4, half-maximal inhibitory concentration: 50200 nM
Compound 4: middle estimate off by 2.5-fold (0.40 log units), on the low side; the range from low to high includes it.
By their numbers in this assay, from the lowest: compounds 1, 3 and 4 (each within the scatter of the next, the first and the last beyond it); then compound 2.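

In this assay, among the compounds shown here, putting methyl in place of fluoro on an aromatic carbon, ortho to a large group, gives a 2.2-fold higher number from compound 1 to compound 4 (0.34 log units; beyond the scatter) and provides the first single-change step in this set. The step is modest, but it shows that this position on the shared core is not indifferent to its substituent: two groups that match in every count computed for them, and differ in the element of the entering atom, can still be told apart here. No available measurement accounts for the step.

With a single step at this position, the compounds shown do not establish how the number would respond to other groups there, such as chloro, methoxy or an amine, or whether the same swap would have a similar effect on a core with a different ring size. Compounds 2 and 3 differ from compound 4 in more than one place, so no steps can be read from those pairs, and the bromo group of compound 3 cannot be placed in a series with fluoro and methyl.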